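Changing the Sulfonamide Nitrogen Substituent in a Small Amide Series

The source may hold more compounds than are shown below. What is called first, only, known or untested is meant among the compounds shown, and "the series" means these compounds.

Compound 1, `O=C(Nc1ccc(Cl)cc1Cl)c1ccc(S(=O)(=O)Nc2ccccc2)cc1`: > 100000 nM
Compound 2, `O=C(Nc1cccc(S(=O)(=O)Nc2ccccc2)c1)c1ccc(Cl)cc1Cl`: > 100000 nM
Compound 3, `CN(c1ccccc1)S(=O)(=O)c1ccc(NC(=O)c2ccc(Cl)cc2Cl)cc1`: 2570 nM

All three compounds were tested in a functional assay on HEK293 cells for agonist activity at probable G-protein coupled receptor 27 (Homo sapiens), read by a luciferase reporter and beta-arrestin recruitment, with a stated time of 10 min; on this read-out lower numbers stand for an effect already at smaller amounts and higher numbers for an effect only at larger amounts of compound. Compound 1 reaches only a limit of the assay, > 100000 nM, so no number is known for it. Compound 2 likewise stops at a limit, > 100000 nM. Compound 3 is the only one of the three with an actual number, 2570 nM, and so it stands alone; the other two sit at the limit of > 100000 nM in this assay, at which 2 of the 3 values shown sit.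

Compound 4, `O=C(Nc1ccc(S(=O)(=O)NCc2ccccc2)cc1)c1ccc(Cl)cc1Cl`, has not yet been measured. It differs from compound 3 in one place: benzylamino in place of methyl(phenyl)amino on a sulfonyl sulfur. The entering group brings one hydrogen-bond donor where the leaving group had none.

Within the data shown here, no measured pair among the three compounds differs in only one place, so no step of this kind has been seen. The expectation for compound 4 rests on compound 3 alone. The expected step is a 5.8-fold higher number from compound 3 to compound 4 (0.77 log units; beyond the scatter), a move beyond the usual scatter toward weaker activity. Compound 4 is therefore estimated at 15000 nM, within 3000 nM to 100000 nM, with a real chance that the assay records only a limit.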

Compound 4, half-maximal effective concentration: > 100000 nM
Compound 4: no number, only a limit (the forecaster's own chance of this, stated with the estimate: 40%); middle value at least 6.6-fold (0.82 log units) away from the limit.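

Among these compounds, replacing methyl(phenyl)amino with benzylamino on a sulfonyl sulfur gives, in this assay, an at least 38-fold higher number from compound 3 to compound 4 (1.59 log units; beyond the scatter), the first readable step between compounds that differ in one place. The two groups have the same heavy atoms joined differently, and the benzylamino group also brings a hydrogen-bond donor, so the step cannot be assigned to the donor or to the ring's attachment alone. Compound 3 remains the only compound with an actual number, and the others share one limit of the assay: the limit of > 100000 nM in this assay, at which 3 of the 4 values shown sit.

As far as these compounds go, with compound 4 at a limit, the true size of the step remains unknown. The compounds shown also leave open how benzyl(methyl)amino, which keeps the benzyl group but has no hydrogen on the nitrogen, or ethyl(phenyl)amino, with a longer chain on that nitrogen, would read out here.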